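The source may report more compounds than this note shows. Statements on the series, on what has been measured and on what is new or still open speak of the compounds shown alone.

Measured compounds:
Compound 1, `O=c1c2cnn(-c3ccc(F)cc3)c2ncn1CC1(O)CCN(Cc2ccc(Br)cc2)CC1`: 6700 nM in an assay on Sf21 cells for inhibition of ubiquitin carboxyl-terminal hydrolase 7 (Homo sapiens), read by spectrophotometry, with stated times of 30 min and 2 h; a higher number here means a weaker inhibitor, a lower number a stronger inhibitor
Compound 2, `O=c1c2cnn(-c3ccc(F)cc3)c2ncn1CC1(O)CCN(Cc2c(Cl)cccc2Cl)CC1`: "not determined" (no result reported) in this assay

Within the data shown here, compound 1 stands alone with the only number given; compound 2 offers no figure to set against it. Compound 3, `O=c1c2cnn(-c3ccc(F)cc3)c2ncn1CC1(O)CCN(Cc2ccc(Br)cc2Cl)CC1`, carries a single change from compound 1: chloro in place of hydrogen on an aromatic carbon, so the 4-bromobenzyl becomes 4-bromo-2-chlorobenzyl. Among the measured compounds shown here, no pair of measured compounds shows what such a change does here, so the step is expected to stay within the usual scatter, with no clear direction: a 1.2-fold lower number from compound 1 to compound 3 (0.09 log units; within the scatter). Compound 3 is therefore estimated at 5500 nM in this assay, most likely between 1800 nM and 17000 nM.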

Compound 3, half-maximal inhibitory concentration: 1900 nM
Estimate against measurement, compound 3: 2.9-fold (0.46 log units) above; measured number inside the range.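

In this assay, the change from 4-bromobenzyl to 4-bromo-2-chlorobenzyl gives a 3.5-fold lower number from compound 1 to compound 3 (0.55 log units; beyond the scatter) and so shows that this position on the 4-bromobenzyl group can shift the inhibition read-out, which a single value could not show. The step is modest and rests on one pair of compounds. Nothing available here explains it.

On these data alone, whether fluoro, methyl or methoxy at the same position would give a similar step remains open. So does whether the step would persist if the bromo group were replaced by hydrogen.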